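From 4-methoxyphenyl to 4-bromophenyl: working notes

The source may report more compounds than this note shows. Statements on the series, on what has been measured and on what is new or still open speak of the compounds shown alone.

Measured in a functional assay on HeLa cells (Homo sapiens) for antiproliferative activity, read by MTT assay, with a stated time of 24 h; on this read-out lower numbers stand for stronger inhibition and higher numbers for weaker inhibition:
compound 1 `Cc1ccc(-c2nn(-c3ccccc3)cc2-c2nc3ccccc3n2S(=O)(=O)c2ccc(C(F)(F)F)cc2)cc1`: 1520 nM
compound 2 `COc1ccc(S(=O)(=O)n2c(-c3cn(-c4ccccc4)nc3-c3ccc(F)cc3)nc3ccccc32)cc1`: 390 nM

Compound 2 holds the lower of the two numbers, and its gap to compound 1 lies beyond the scatter. Compound 3 `O=S(=O)(c1ccc(Br)cc1)n1c(-c2cn(-c3ccccc3)nc2-c2ccc(F)cc2)nc2ccccc21`, not yet measured in this assay, keeps the frame of compound 2 and has bromo in place of methoxy on an aromatic carbon, para to a large group (bromo in place of methoxy on an aromatic carbon). Within the data shown here, the data hold no step for this change alone, since compound 1 and compound 2 differ in more than one place, so the expectation is loose. A small rise in the number is expected, probably within the scatter, and the estimated size is a 1.5-fold higher number from compound 2 to compound 3 (0.19 log units; within the scatter). For compound 3 the expected value is 600 nM, with an estimated range of 200 nM to 1800 nM.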

Compound 3, half-maximal inhibitory concentration: 2040 nM
Compound 3: middle estimate off by 3.4-fold (0.53 log units), on the low side; measured number above the stated range.
By their numbers in this assay, from the lowest: compound 2; then compounds 1 and 3 (each within the scatter of the next).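

In this assay, among these compounds, the change from 4-methoxyphenyl to 4-bromophenyl gives the only single-place step so far: a 5.2-fold higher number from compound 2 to compound 3 (0.72 log units; beyond the scatter). With the rest of compound 2 kept, the group on this aromatic carbon clearly affects the antiproliferative read-out, and methoxy is the better of the two groups compared here. Nothing available explains the size of this step.

A single step cannot show whether methoxy is unusually favourable at this place or bromo unusually unfavourable; an ethoxy, a dimethylamino group or a chloro group on the same carbon would help separate the two readings. As far as these compounds go, it also remains open whether the same change would give a similar step with the other parts of the frame altered, as they are in compound 1.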